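Phenyl in place of pentyl: expectation for compound 4

The source may report more compounds than this note shows. Statements on the series, on what has been measured and on what is new or still open speak of the compounds shown alone.

Measured so far in an in vitro assay on HEK-tsA201 cells for antagonist activity at Neuronal acetylcholine receptor; alpha3/beta4 (Homo sapiens), read by fluorescence and calcium flux; a lower number here means a stronger inhibitor, a higher number a weaker inhibitor:
Compound 1 `CCCOc1ccc(C(=O)Nc2cccc(Cl)n2)cc1` gives > 100000 nM, a limit of the assay.
Compound 2 `CCCNc1cccc(NC(=O)c2ccc(OCCC)cc2)n1` gives 12600 nM.
Compound 3 `CCCCCNc1cccc(NC(=O)c2ccc(OCCC)cc2)n1` gives > 100000 nM, also a limit.

Compound 3 thus stands at the limit of this assay, shared by one other value (the limit of > 100000 nM in this assay, at which 2 of the 3 values shown sit). Compound 4 `CCCOc1ccc(C(=O)Nc2cccc(Nc3ccccc3)n2)cc1` differs from it by phenyl in place of pentyl on a nitrogen on an aromatic ring. Within the data shown here, no measured step swaps a chain for a ring on this nitrogen; the nearest evidence is an at least 7.9-fold higher number from compound 2 to compound 3 (0.89 log units; beyond the scatter) and an at least 7.9-fold lower number from compound 1 to compound 2 (0.89 log units; beyond the scatter), showing that a shorter substituent on this nitrogen gives a readable number while the longer one does not. The step of an at least 2.0-fold lower number from compound 3 to compound 4 (0.30 log units; that floor lies within the scatter) is therefore expected to be modest and downward at best, with a real chance that only a limit is read again. Compound 4 is estimated at 50000 nM, range 10000 nM to 300000 nM.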

Compound 4, half-maximal inhibitory concentration: > 100000 nM
Compound 4 ended at the assay's limit; the forecaster's own chance of this, stated with the estimate: 55%; middle value at least 2.0-fold (0.30 log units) away from the limit.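

In this assay, a ring on this nitrogen gives no readable number any more than the pentyl chain does, so compound 2 remains the only compound with one: the limit of > 100000 nM in this assay, at which 3 of the 4 values shown sit.

Against propyl, phenyl reads as an at least 7.9-fold higher number from compound 2 to compound 4 (0.89 log units; beyond the scatter). The steps from compound 1 and from compound 3 to compound 4 cannot be read, since both ends are limits.

Open, from the compounds shown here alone, is whether ethyl, isopropyl or benzyl on this nitrogen would give a lower number than compound 2 does. Also open, going by these compounds, is whether a substituted phenyl, such as 4-methoxyphenyl, would bring a ring back into readable range.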